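Ring Substituent Change from Compound 2 to Compound 3

The compounds below may be only part of what the source reports. "The series", "measured", "known", "first", "only" and "open" are said of these compounds alone.

Of the compounds shown here, two have been measured in a functional assay on NCI-H460 cells (Homo sapiens) for cytotoxicity, read by sulforhodamine B assay; on this read-out lower numbers stand for stronger inhibition of growth and higher numbers for weaker inhibition of growth. Compound 2 `CC1=CC[C@@H]([C@@](C)(O)CCCC(C)(C)NC(=S)N/N=C\c2ccccc2[N+](=O)[O-])CC1` gives 20600 nM, and compound 1 `CC1=CC[C@@H]([C@@](C)(O)CCCC(C)(C)NC(=S)N/N=C\c2ccc(N(C)C)cc2)CC1` gives 19600 nM; the two numbers lie within the scatter of each other, so neither stands apart. Within the data shown here, the single measured step, a 1.1-fold higher number from compound 1 to compound 2 (0.02 log units; within the scatter), shows that exchanging one substituted phenyl for another on the carbon with a double bond to nitrogen left the read-out unchanged. Compound 3 `CC1=CC[C@@H]([C@@](C)(O)CCCC(C)(C)NC(=S)N/N=C\c2ccccc2Cl)CC1` carries the change (chloro in place of nitro on an aromatic carbon). Among the measured compounds shown here, this is the same kind of move, a substituent exchange on that aromatic ring with the rest of the structure kept, and the one comparable step lay within the scatter. For the measured compounds named here, no other measured pair bears on it. The expected step is therefore a 1.0-fold lower number from compound 2 to compound 3 (0.01 log units; within the scatter), with no shift beyond the scatter in either direction. Compound 3 is estimated at 20000 nM, within a range from 8000 nM to 50000 nM.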

Compound 3, concentration for 50% growth inhibition: 24600 nM
Estimate against measurement, compound 3: 1.2-fold (0.09 log units) below; the measured number falls inside the stated range.
By their numbers in this assay, from the lowest: compounds 1, 2 and 3 (each within the scatter of the next).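

In this assay, chloro in place of nitro on an aromatic carbon ortho to a large group gives a 1.2-fold higher number from compound 2 to compound 3 (0.08 log units; within the scatter), so at this position a single chlorine atom and the larger nitro group are not told apart by the read-out. The comparison with the 4-(dimethylamino)phenyl compound reads the same way, with a 1.3-fold higher number from compound 1 to compound 3 (0.10 log units; within the scatter), and all three aryl groups now lie within the scatter of one another, so a halogen joins the two earlier substituents without any separation. No data at hand offer an explanation for this lack of separation.

From the compounds shown here alone, it remains open whether the read-out stays this flat with a carboxylic acid or a primary amine on the aromatic ring. The compounds shown also do not tell whether a change elsewhere in the shared core, such as a longer chain, would move the number at all.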